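This account rests on a few compounds, and the source may have more. Where it says the series, first, only, none or still open, it means among the compounds named here.

The measured compounds:
compound 1, `Cc1c(C=O)cc(-c2ccc(S(C)(=O)=O)cc2)n1-c1ccc(F)c(F)c1`, giving 52% in a functional assay on the whole organism (strain Swiss albino) for inhibition, with Mus musculus as the target, in the writhing test, with a stated time of 30 min, at a dose of 20 mg/kg by the oral route; a lower number here means a weaker effect, a higher number a stronger effect of the compound at the dose given;
compound 2, `Cc1c(C=O)cc(-c2ccc(S(C)(=O)=O)cc2)n1-c1ccccc1`, giving 32% in this assay;
compound 3, `Cc1c(/C=N\O)cc(-c2ccc(S(C)(=O)=O)cc2)n1-c1ccc(F)c(F)c1`, giving 27% in this assay.

Compound 4, `Cc1c(/C=N\O)cc(-c2ccc(S(C)(=O)=O)cc2)n1-c1ccccc1`, has not yet been measured in this assay. It differs from compound 3 by phenyl in place of 3,4-difluorophenyl on an aromatic nitrogen. The same kind of change is made from compound 1 to compound 2, namely (phenyl in place of 3,4-difluorophenyl on an aromatic nitrogen); there the place lies two ring bonds from the ring atom that bears a formyl group (2 heavy atoms), whereas in compound 3 that ring atom bears a group of 3 heavy atoms. The two cores differ by a group of 3 heavy atoms (1 carbon, 1 nitrogen, 1 oxygen; no ring) in place of a group of 2 heavy atoms (1 carbon, 1 oxygen; no ring), on an aromatic carbon, and that difference gave a number 25 percentage points lower from compound 1 to compound 3 (beyond the scatter). The exchange of the aryl group on the ring nitrogen gave a number 20 percentage points lower from compound 1 to compound 2 (beyond the scatter). Compound 2 and compound 3 lie within the scatter of each other.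

Beside that earlier step, a step of a number 15 percentage points lower from compound 3 to compound 4 (beyond the scatter) is expected. It is taken smaller because a number 20 percentage points lower from compound 1 to compound 2 (beyond the scatter) started from a higher number, while compound 3 already gives only 27%, leaving little room for a further fall. Compound 4 is thus estimated at 12%, between 0% and 30%.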

Compound 4, a percentage reported as inhibition, in the whole organism at one dose (the size of the read-out at that dose, not a potency): 53%
Beside the measured number, compound 4's estimate is 41 percentage points below it, and the stated range ends below it.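

In this assay, phenyl in place of 3,4-difluorophenyl on the aromatic nitrogen gave a number 26 percentage points higher from compound 3 to compound 4 (beyond the scatter), and this does not repeat the earlier step on the core of compound 1: the same change on two cores in this assay, a number 20 percentage points lower (beyond the scatter) from compound 1 to compound 2 and a number 26 percentage points higher (beyond the scatter) from compound 3 to compound 4, 46 percentage points apart, beyond the scatter of two such steps The group of 3 heavy atoms in place of the formyl group gave a number 21 percentage points higher from compound 2 to compound 4 (beyond the scatter), and this change also depends on the core: the same change on two cores in this assay, a number 25 percentage points lower (beyond the scatter) from compound 1 to compound 3 and a number 21 percentage points higher (beyond the scatter) from compound 2 to compound 4, 46 percentage points apart, beyond the scatter of two such steps In this series, therefore, neither change can be carried from one core to the other, as the effect of each depends on the group at the other place; yet this rests on a single set of four compounds at one dose, and it does not show why the steps reverse or whether potency differs.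

The compounds shown leave open whether the reversal persists with other groups on the aromatic nitrogen, such as a longer alkyl chain. They also leave open what happens with a carboxylic acid or a nitrile in place of the formyl group.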